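Nitro for Formyl on the Sulfonyl Arm of Compound 3

The source may hold more compounds than are shown below. What is called first, only, known or untested is meant among the compounds shown, and "the series" means these compounds.

Compound 1, `COc1ccc(-c2cc(=O)c3c(OC)cc(OC)cc3[nH]2)cc1`, in a functional assay on SUP-B15 cells (Homo sapiens) for antiproliferative activity, with a stated time of 72 h; on this read-out lower numbers stand for an effect already at smaller amounts and higher numbers for an effect only at larger amounts of compound: > 62000 nM, a limit of the assay and not a number.
Compound 2, `C=CCNC(=O)n1c(-c2ccc(OC)cc2)cc(=O)c2c(OC)cc(OC)cc21`, in this assay: 16000 nM.
Compound 3, `COc1ccc(-c2cc(=O)c3c(OC)cc(OC)cc3n2S(=O)(=O)c2ccc(C=O)cc2)cc1`, in this assay: > 34400 nM, again a limit of the assay.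

Compound 3 therefore stands only at a limit in this assay, as shown by the limit of > 34400 nM in this assay, at which 1 of the 3 values shown sits, and one of the other two values is a limit as well, (the limit of > 62000 nM in this assay, at which 1 of the 3 values shown sits). The measured steps concern the group on the aromatic nitrogen of the shared core: an at least 3.8-fold lower number from compound 1 to compound 2 (0.58 log units; beyond the scatter); a step that the two limits leave unreadable from compound 1 to compound 3; an at least 2.1-fold higher number from compound 2 to compound 3 (0.33 log units; beyond the scatter). None of them touches the formyl group that now changes.

Compound 4, `COc1ccc(-c2cc(=O)c3c(OC)cc(OC)cc3n2S(=O)(=O)c2ccc([N+](=O)[O-])cc2)cc1`, differs from compound 3 only in that change: nitro in place of formyl on an aromatic carbon. For the measured compounds named here, with no measured step bearing on this position, the expectation is a step from compound 3 to compound 4 of a step that the limit leaves unreadable from compound 3 to compound 4 in this assay, that is, none beyond the scatter. Compound 4 is estimated to give 50000 nM in this assay, within a range of 15000 nM to 200000 nM, most likely again reported only as a limit.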

Compound 4, half-maximal effective concentration: 17100 nM
Estimate against measurement, compound 4: 2.9-fold (0.47 log units) above, and the stated range covers the measured number.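

Formyl and nitro sit on the same aromatic carbon of the sulfonyl arm, para to a large group, and this pair is the only measured change at that position, since the earlier steps all concern the group on the aromatic nitrogen. In this assay, going from 4-formylphenyl to 4-nitrophenyl gives an at least 2.0-fold lower number from compound 3 to compound 4 (0.30 log units; that floor lies within the scatter), and with it the sulfonyl arm gains a compound that returns an actual number and not just a limit of the assay. The size of this step can be stated only as a floor, and that floor cannot be told apart from ordinary scatter, because the value for compound 3 is a limit and not a number: the limit of > 34400 nM in this assay, at which 1 of the 4 values shown sits.

A single pair cannot show what it is about nitro, or about the loss of formyl, that lies behind this result, so no trend can be drawn for this position. An amine or a carboxylic acid on the same aromatic carbon, or a simple hydrogen there, would show whether the number depends on the group at this place at all.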